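Chloro for methyl on the aryl arm of compound 1

The source may report more compounds than this note shows. Statements on the series, on what has been measured and on what is new or still open speak of the compounds shown alone.

Measured compounds in a functional assay on the whole organism (strain Wistar) for inhibition, with Rattus norvegicus as the target, read by paw edema, with stated times of 30 min and 120 min, at a dose of 50 mg/kg by the oral route; on this read-out lower numbers stand for less inhibition and higher numbers for more inhibition at the one dose given (going by the name of the read-out):
- compound 1 `Cc1ccc(C2=NN(c3ccc([N+](=O)[O-])cc3)C(c3cn(-c4ccccc4)nc3-c3ccc(Cl)c(Cl)c3)C2)cc1` gives 71.9%
- compound 2 `CCC(=O)N1N=C(c2ccc(C)cc2)CC1c1cn(-c2ccccc2)nc1-c1ccc(Cl)c(Cl)c1` gives 70.3%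
- compound 3 `Cc1ccc(C2=NNC(c3cn(-c4ccccc4)nc3-c3ccc(Cl)c(Cl)c3)C2)cc1` gives 48.4%

Compound 1 carries the highest of the three numbers, yet compound 2 lies within the scatter of it, so no order between them can be read; only compound 3 stands clearly apart, being lowest. The shared core is the same throughout; the measured steps all concern the substituent on an amine nitrogen in a ring: a number 1.6 percentage points lower from compound 1 to compound 2 (within the scatter), a number 23.5 percentage points lower from compound 1 to compound 3 (beyond the scatter), a number 21.9 percentage points lower from compound 2 to compound 3 (beyond the scatter).

Compound 4 `O=[N+]([O-])c1ccc(N2N=C(c3ccc(Cl)cc3)CC2c2cn(-c3ccccc3)nc2-c2ccc(Cl)c(Cl)c2)cc1` differs from compound 1 elsewhere: chloro in place of methyl on an aromatic carbon. Within the data shown here, none of the measured steps touches this aromatic carbon, so nothing speaks directly to the change. With the nitrogen substituent of compound 1 kept, the expectation is a step of no more than the scatter, a number 1.9 percentage points lower from compound 1 to compound 4 (within the scatter), in no settled direction. Compound 4 is therefore estimated at 70%, with a range from 56% to 82%.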

Compound 4, a percentage reported as inhibition, in the whole organism at one dose (the size of the read-out at that dose, not a potency): 69.5%
Compound 4: the middle estimate sits 0.5 percentage points above what was measured; the measured number falls inside the stated range.
By their numbers in this assay, from the lowest: compound 3; then compounds 4, 2 and 1 (each within the scatter of the next).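

In this assay, chloro in place of methyl gives a number 2.4 percentage points lower from compound 1 to compound 4 (within the scatter). Among these compounds, this is the only measured step away from the nitrogen substituent, and it shows that, with 4-nitrophenyl kept on the ring nitrogen, 4-chlorophenyl and 4-methylphenyl cannot be told apart on this read-out, so this aromatic carbon takes either group without a change beyond the scatter. Nothing available explains this result.

The compounds shown leave open whether the same exchange behaves alike with propanoyl or hydrogen on the ring nitrogen, where the read-out did separate compound 3 from compound 1. They also leave open what a different kind of group on this aromatic carbon would do, such as an amine, a carboxylic acid or a longer alkyl chain.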